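Benzyloxy to 4-aminophenoxy: a step with no measured precedent

A few compounds are considered here, and "the series" means these few. Any claim that something is new, unique, unknown or untested is made for them only; others in the source may bear on it.

The measured compounds and their values:
Compound 1 `O=S(=O)(NCCNC(=S)Nc1ccc(Cl)cc1)c1ccc(-c2ccccc2OCc2ccccc2)s1` gives > 50000 nM in a functional assay on RS4-11 cells (Homo sapiens) for inhibition, read by CCK-8 assay, with a stated time of 48 h; on this read-out higher numbers stand for weaker inhibition and lower numbers for stronger inhibition; this is a limit of the assay, not a number.
Compound 2 `Cc1cc(C)cc(NC(=O)NCCNS(=O)(=O)c2ccc(-c3ccccc3OCc3ccccc3)s2)c1` gives > 50000 nM in this assay; this too is a limit of the assay.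
Compound 3 `O=[N+]([O-])c1ccc(NC(=S)NCCNS(=O)(=O)c2ccc(-c3ccccc3OCc3ccccc3)s2)cc1` gives 11300 nM in this assay.

Compound 2 therefore stands at the limit, a place it shares with one other value (the limit of > 50000 nM in this assay, at which 2 of the 3 values shown sit). The step from compound 1 to compound 2 is a step that the two limits leave unreadable from compound 1 to compound 2, while the two steps into compound 3, an at least 4.4-fold lower number from compound 1 to compound 3 (0.64 log units; beyond the scatter) and an at least 4.4-fold lower number from compound 2 to compound 3 (0.64 log units; beyond the scatter), are at least modest and beyond the scatter.

Compound 4 `Cc1cc(C)cc(NC(=O)NCCNS(=O)(=O)c2ccc(-c3ccccc3Oc3ccc(N)cc3)s2)c1` differs from compound 2 by 4-aminophenyl in place of benzyl on an oxygen on an aromatic ring. Among the compounds with values here, none of the measured steps touches this position; all of them concern the group on the amine nitrogen at the other end of the shared core, so none of them bears on the change from compound 2 to compound 4. Within the data shown here, with no precedent and compound 2 sitting at the limit, the expected step is an at least 1.2-fold lower number from compound 2 to compound 4 (0.09 log units; that floor lies within the scatter), which may be no more than the scatter in either direction. Compound 4 is therefore estimated at 40000 nM, with a range from 8000 nM to 150000 nM.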

Compound 4, half-maximal inhibitory concentration: > 20000 nM
Compound 4 ended at the assay's limit (the forecaster's own chance of this, stated with the estimate: 60%); the middle value is on the limit's open side.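

Compound 2 and compound 4 both end at limits of this assay, and no step can be read between them. The compounds shown leave open whether 4-aminophenyl in place of benzyl on an oxygen on an aromatic ring changes the read-out at all, and in which direction.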